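Swapping the Amine Tail: Pyrrolidine to Phenylpiperazine

The compounds below may be only part of what the source reports. "The series", "measured", "known", "first", "only" and "open" are said of these compounds alone.

Measured compounds:
compound 1 `CCN(CC)CC(=O)NCCNc1cc(/C=C/c2ccccc2)nc2ccccc12` gives 700 nM
compound 2 `O=C(CN1CCCC1)NCCNc1cc(/C=C/c2ccccc2)nc2ccccc12` gives 12500 nM

Both compounds were tested in an ADME assay on J774 cells (Mus musculus) for cytotoxicity, read by MTT assay, with a stated time of 48 h; a lower number here means a stronger inhibitor, a higher number a weaker inhibitor. Compound 2 stands at the high end of the two numbers, with the nearest neighbour being compound 1 at a step of an 18-fold higher number from compound 1 to compound 2 (1.25 log units; beyond the scatter). That single step is the only one measured, and it shows that changing the amine on the saturated chain carbon bound to the carbonyl carbon can move the number by a large amount.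

Compound 3 `O=C(CN1CCN(c2ccccc2)CC1)NCCNc1cc(/C=C/c2ccccc2)nc2ccccc12` has not yet been tested. It differs from compound 2 in one place: 4-phenylpiperazin-1-yl in place of pyrrolidin-1-yl on a saturated chain carbon bound to a carbonyl carbon. The measured step touches the same position, so it bears on this change, but it replaced one amine with another of similar size, whereas here a larger group with an added aromatic ring enters. Within the data shown here, no measured step shows what such an addition does here, so the direction cannot be read from the numbers at hand.

Given that the measured step was large, a step beyond the scatter is plausible either way, and the estimate for compound 3 is a middle-of-the-road 5000 nM with a range from 1200 nM to 25000 nM, corresponding to an expected step of a 2.5-fold lower number from compound 2 to compound 3 (0.40 log units; beyond the scatter).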

Compound 3, half-maximal inhibitory concentration: 4500 nM
Compound 3: middle estimate off by 1.1-fold (0.05 log units), on the high side; the measured number falls inside the stated range.
By their numbers in this assay, from the lowest: compound 1; then compound 3; then compound 2.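

In this assay, the saturated chain carbon bound to a carbonyl carbon accepts 4-phenylpiperazin-1-yl, a much larger group with an added aromatic ring, without the number rising above that of the pyrrolidin-1-yl compound. Instead, the change gives (a 2.8-fold lower number from compound 2 to compound 3 (0.44 log units; beyond the scatter)), so a larger amine at this place does not by itself push the number up. It does not match diethylamino, however, as the comparison with the open-chain amine gives (a 6.4-fold higher number from compound 1 to compound 3 (0.81 log units; beyond the scatter)), which leaves compound 1 with the lowest number of the three.

The compounds shown cannot separate the contribution of the piperazine ring from that of its phenyl ring, a question that 4-methylpiperazin-1-yl or piperidin-1-yl at this place would address. Nothing available here explains why these three amines give such different numbers.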